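The compounds below may be only part of what the source reports. "The series", "measured", "known", "first", "only" and "open" are said of these compounds alone.

Measured so far in an assay on CHO cells for displacement of a labelled ligand from adenosine receptor A2b (Homo sapiens), read by scintillation counting, with a stated time of 75 min, in the presence of a further agent that is not named here; on this read-out lower numbers stand for stronger inhibition and higher numbers for weaker inhibition:
compound 1 `CCCn1c(=O)[nH]c2nc(-c3ccc(S(=O)(=O)N4CCN(c5ccc(Cl)cc5F)CC4)cc3)[nH]c2c1=O` gives 1.91 nM
compound 2 `CCCn1c(=O)[nH]c2nc(-c3ccc(S(=O)(=O)N4CCN(c5ccccc5C)CC4)cc3)[nH]c2c1=O` gives 0.432 nM

Within the data shown here, compound 2 stands at the lowest of the two numbers; the single measured step, a 4.4-fold lower number from compound 1 to compound 2 (0.65 log units; beyond the scatter), lies beyond the scatter. Compound 3 `CCCn1c(=O)[nH]c2nc(-c3ccc(S(=O)(=O)N4CCN(c5cccc(Br)c5)CC4)cc3)[nH]c2c1=O` is not yet measured. Its change from compound 2 is 3-bromophenyl in place of 2-methylphenyl on an amine nitrogen in a ring. Among the measured compounds shown here, only the one measured step bears on this, and loosely: there 4-chloro-2-fluorophenyl gave way to 2-methylphenyl and the number fell. Returning to a phenyl that carries a halogen is therefore expected to raise the number modestly, a 2.8-fold higher number from compound 2 to compound 3 (0.44 log units; beyond the scatter). Compound 3 is estimated at 1.2 nM, with a range of 0.4 nM to 4 nM.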

Compound 3, inhibition constant: 0.234 nM
Beside the measured number, compound 3's estimate is 5.1-fold (0.71 log units) above it, outside the stated range (below it).
By their numbers in this assay, from the lowest: compounds 3 and 2 (each within the scatter of the next); then compound 1.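

In this assay the amine nitrogen in a ring carries 3-bromophenyl as readily as 2-methylphenyl, with a 1.8-fold lower number from compound 2 to compound 3 (0.27 log units; within the scatter), so a halogen on the phenyl does not by itself go with a higher number. Compound 1 stays apart from both, with an 8.2-fold lower number from compound 1 to compound 3 (0.91 log units; beyond the scatter), which ties the higher number to 4-chloro-2-fluorophenyl rather than to halogen-bearing phenyls in general. Nothing available explains these differences.

Open, as far as these compounds go, is how an unsubstituted phenyl, or a phenyl carrying an amine or a carboxylic acid, compares on this nitrogen.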